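This account rests on a few compounds, and the source may have more. Where it says the series, first, only, none or still open, it means among the compounds named here.

Compound 2 `Cc1nc2ccc(CN(CCN)c3ccc(C(=O)N[C@@H](CCC(=O)O)C(=O)O)c(F)c3)cc2c(=O)[nH]1` stands at the high end of the three numbers available: in an assay on isolated protein for inhibition of Thymidylate synthase (Mus musculus) (a higher number here means a weaker inhibitor, a lower number a stronger inhibitor), compound 2 gives 11700 nM, well beyond the scatter from either neighbour. Compound 3 `CCN(Cc1ccc2nc(C)[nH]c(=O)c2c1)c1ccc(C(=O)N[C@@H](CCC(=O)O)C(=O)O)cc1F` in this assay gives 680 nM, and compound 1 `C=CCN(Cc1ccc2nc(C)[nH]c(=O)c2c1)c1ccc(C(=O)N[C@@H](CCC(=O)O)C(=O)O)cc1` in this assay gives 480 nM; those two lie within the scatter of each other, so no order can be read between them.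

Compound 4 `Cc1nc2ccc(CN(C)c3ccc(C(=O)N[C@@H](CCC(=O)O)C(=O)O)c(F)c3)cc2c(=O)[nH]1` has not yet been measured in this assay. It differs from compound 2 in one place: hydrogen in place of aminomethyl on a saturated chain carbon bound to a nitrogen on an aromatic ring. Cut one bond further out, the same difference reads 2-aminoethyl to methyl, so the substituent on the nitrogen of compound 4 is smaller than the ethyl of compound 3 by one carbon.

Compound 3 in this assay at 680 nM suggests that a short saturated substituent on that nitrogen is compatible with a low number, so a downward step is expected for compound 4, estimated as a 12-fold lower number from compound 2 to compound 4 (1.07 log units; beyond the scatter), a step well beyond the scatter. Compound 4 is therefore expected to give about 1000 nM in this assay, with a likely range from 400 nM to 3500 nM.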

Compound 4, half-maximal inhibitory concentration: 120 nM
The estimate for compound 4 lay 8.3-fold (0.92 log units) above the measured number; the measured number lies below the stated range.
By their numbers in this assay, from the lowest: compound 4; then compounds 1 and 3 (each within the scatter of the next); then compound 2.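

In this assay, among these compounds, the single change from the 2-aminoethyl chain to a methyl on the same nitrogen gives a 98-fold lower number from compound 2 to compound 4 (1.99 log units; beyond the scatter) and is a large step. Among the compounds shown here, this is the first direct reading at this position, since none of the earlier compounds differed from one another in only one place, and it shows that the substituent here can move the number strongly, with the 2-aminoethyl form being the weaker of this pair. Nothing measured here accounts for the size of the step.

The compounds shown leave open whether the terminal amine or the length of the chain matters more, a question that a propyl or 2-hydroxyethyl group on this nitrogen would address. They also leave open whether a hydrogen on that nitrogen, or a longer chain ending in a carboxylic acid, would fit the same trend.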